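A few compounds are considered here, and "the series" means these few. Any claim that something is new, unique, unknown or untested is made for them only; others in the source may bear on it.

Working notes on the series in a functional assay on K562 cells (Homo sapiens) for cytotoxicity, read by MTT assay, with a stated time of 48 h; a lower number here means a stronger inhibitor, a higher number a weaker inhibitor. Compound 1 `CCOC(=O)C1(C(=O)Nc2ccccc2)CC1c1cc(OC)c(OC)c(OC)c1` gives only a limit, > 100000 nM; > 100000 nM (2 entries). Compound 2 `CCOC(=O)[C@]1(C(=O)Nc2ccccc2)C[C@@H]1c1cc(OC)c(OC)c(OC)c1`, drawn with a defined configuration, also gives only a limit, > 100000 nM, so it offers no single number as a starting point. Compound 3 `CCOC(=O)C1(C(=O)Nc2ccccc2Cl)CC1c1cc(OC)c(OC)c(OC)c1` does give numbers, 41400 nM; 14200 nM (2 entries), and its two entries lie some way apart.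

Compound 4 `CCOC(=O)[C@]1(C(=O)Nc2ccccc2Cl)C[C@@H]1c1cc(OC)c(OC)c(OC)c1` is the next to be read. Against compound 2 the change is chloro in place of hydrogen on an aromatic carbon, ortho to a large group, taking phenyl to 2-chlorophenyl. Going by the values given here, the only compound here with numbers, compound 3 at 41400 nM; 14200 nM (2 entries), also carries the 2-chlorophenyl group, so a numeric reading is expected. For compound 4 a result at the limit remains possible. The expected step is an at least 4.5-fold lower number from compound 2 to compound 4 (0.65 log units; beyond the scatter), towards stronger inhibition and beyond the scatter. For compound 4 the estimated value is 22000 nM, with an expected range of 7000 nM to 75000 nM.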

Compound 4, half-maximal inhibitory concentration: 19500 nM
Estimate against measurement, compound 4: 1.1-fold (0.05 log units) above; measured number inside the range.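

In this assay, chloro in place of hydrogen on an aromatic carbon, ortho to a large group, taking phenyl to 2-chlorophenyl, gives an at least 5.1-fold lower number from compound 2 to compound 4 (0.70 log units; beyond the scatter). Compound 2 gives only a limit, > 100000 nM, so this step is a bound and its full size cannot be read. A numeric reading with 2-chlorophenyl is now no longer confined to compound 3, and it also holds for a compound with a defined configuration, while the spread of compound 3 remains wide: the several entries of compound 3 in this assay, 41400 nM; 14200 nM (2 entries).

The compounds shown leave open whether a fluoro, a methoxy or an amino group in the same place would give a comparable step. They also leave open any role of configuration, as compound 3 and compound 4 differ in how they are drawn: the fact that one of compounds 3 and 4 is drawn with a defined configuration and the other without, at the place where they differ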